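Adding a Fluorine to a Urea Tested on Rice

A few compounds are considered here, and "the series" means these few. Any claim that something is new, unique, unknown or untested is made for them only; others in the source may bear on it.

Compound 1 `C[C@H](NC(=O)Nc1cccc(C(F)(F)F)c1)c1ccccc1` is a urea tested in an ADME assay on the whole organism with Oryza sativa as the target, tested at 1 uM (a lower number here means a stronger effect, a higher number a weaker effect of the compound at the concentration tested), where compound 1 gives 93%. Compound 2 `COc1cccc(NC(=O)N[C@@H](C)c2ccccc2)c1` gives 99%. For the measured compounds named here, the one measured step, a number 6 percentage points higher from compound 1 to compound 2 (within the scatter), lies within the scatter, so compound 1 stands within the scatter of compound 2 on these two numbers. Compound 3 `C[C@H](NC(=O)Nc1cccc(C(F)(F)F)c1F)c1ccccc1` differs from compound 1 by fluoro in place of hydrogen on an aromatic carbon. Going by the values given here, no measured step concerns this kind of change, and the only step seen stayed within the scatter, so the expected step of a number 3 percentage points lower from compound 1 to compound 3 (within the scatter) is none beyond the scatter. Compound 3 is therefore estimated at 90%, between 72% and 100%.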

Compound 3, a percentage reported as activity, at one concentration (the size of the read-out at that concentration, not a potency): 98%
For compound 3 the middle estimate is 8 percentage points below the measured one; the measured number falls inside the stated range.
By their numbers in this assay, from the lowest: compounds 1, 3 and 2 (each within the scatter of the next).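

Fluoro in place of hydrogen on an aromatic carbon, ortho to a trifluoromethyl group, gives a number 5 percentage points higher from compound 1 to compound 3 (within the scatter) in this assay on the whole plant. At this position, then, the added fluorine leaves the read-out indistinguishable from that of the parent with hydrogen, so this small change shows no effect that can be told apart from ordinary scatter. No outside information accounts for this result.

From the compounds shown here alone, whether a larger group at this same carbon, such as an amine or a carboxylic acid, would move the number beyond the scatter remains open. So does whether any change to the urea itself would do so.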